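Cytotoxicity expected for a fluoro analogue of compound 2

The compounds below may be only part of what the source reports. "The series", "measured", "known", "first", "only" and "open" are said of these compounds alone.

Compound 2 `CCS(=O)(=O)Nc1ccc(NC(=O)c2cccc(C(F)(F)F)c2)cc1Cl` is examined in an ADME assay on HEK293 cells (Homo sapiens) for cytotoxicity, read by MTT assay, with a stated time of 48 h (on this read-out higher numbers stand for weaker inhibition and lower numbers for stronger inhibition), where compound 2 gives 159000 nM. Compound 1 `CCS(=O)(=O)Nc1ccc(NC(=O)c2cccc(C(F)(F)F)c2)cc1OC` sits at the assay limit > 250000 nM, namely (the limit of > 250000 nM in this assay, at which 1 of the 3 values shown sits). Compound 3 `CCS(=O)(=O)Nc1ccc(NC(=O)c2cc(C(F)(F)F)cc(C(F)(F)F)c2)cc1Cl` gives 32200 nM. Among the numbers shown, compound 2 stands highest, with a 4.9-fold lower number from compound 2 to compound 3 (0.69 log units; beyond the scatter) on trifluoromethyl in place of hydrogen on an aromatic carbon. Compound 4 `CCS(=O)(=O)Nc1ccc(NC(=O)c2cccc(C(F)(F)F)c2)cc1F` differs from compound 2 by fluoro in place of chloro on an aromatic carbon. Among the measured compounds shown here, the only measured step at that same place is an at least 1.5-fold lower number from compound 1 to compound 2 (0.19 log units; that floor lies within the scatter), a floor that lies within the scatter; the other step concerns a different place and offers no guide. Compound 4 is therefore expected to show no step beyond the scatter, a 1.1-fold higher number from compound 2 to compound 4 (0.05 log units; within the scatter). The estimate for compound 4 is 180000 nM, between 70000 nM and 400000 nM.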

Compound 4, half-maximal inhibitory concentration: 94800 nM
Compound 4: middle estimate off by 1.9-fold (0.28 log units), on the high side; the range from low to high includes it.
By their numbers in this assay, from the lowest: compound 3; then compounds 4 and 2 (each within the scatter of the next). At a limit, above all of these: compound 1.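

In this assay, the two halogens at this position are not separated: a 1.7-fold lower number from compound 2 to compound 4 (0.22 log units; within the scatter). Fluoro in place of methoxy gives an at least 2.6-fold lower number from compound 1 to compound 4 (0.42 log units; beyond the scatter), the first step at this position that lies beyond the scatter, whereas the floor for chloro in place of methoxy did not. That step is only a floor, since the number for compound 1 is a limit: the limit of > 250000 nM in this assay, at which 1 of the 4 values shown sits.

The compounds shown leave open how an amine, a hydroxy group or plain hydrogen would read at this position. They also leave open whether fluoro here would match chloro alongside the added trifluoromethyl of compound 3.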